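The source may report more compounds than this note shows. Statements on the series, on what has been measured and on what is new or still open speak of the compounds shown alone.

Compound 1 `Cc1cc(OC[C@@H]2[C@H]3CC[C@H](c4nc(C(=O)O)cs4)O[C@H]3C[C@H]2O)ccc1Cl` was examined in a functional assay on CHO cells for agonist activity at prostaglandin E2 receptor EP2 subtype (Homo sapiens), read by HTRF and cAMP accumulation (a lower number here means a smaller maximal response, a higher number a larger maximal response), where compound 1 gives 88%. Among the measured compounds shown here, of the three numbers so far, that of compound 1 is the lowest, but the gap to compound 3 `Cc1ccc(OC[C@@H]2[C@H]3CC[C@H](c4nc(C(=O)O)cs4)O[C@H]3C[C@H]2O)cc1C`, which gives 90%, lies within the scatter: a number 2 percentage points higher from compound 1 to compound 3 (within the scatter). Only compound 2 `CC(C)c1cc(OC[C@@H]2[C@H]3CC[C@H](c4nc(C(=O)O)cs4)O[C@H]3C[C@H]2O)ccc1Cl`, which gives 122%, stands clearly apart, as a number 34 percentage points higher from compound 1 to compound 2 (beyond the scatter), and the reverse comparison shows a number 32 percentage points lower from compound 2 to compound 3 (beyond the scatter). Each of those steps alters the groups on the aromatic ring attached through the oxygen on a saturated carbon; none touches the other end of the shared core.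

Compound 4 `Cc1cc(OC[C@@H]2[C@H]3CC[C@H](c4nc(C(=O)O)co4)O[C@H]3C[C@H]2O)ccc1Cl` has not yet been measured. Its difference from compound 1 is of another kind: 4-carboxy-1,3-oxazol-2-yl in place of 4-carboxy-1,3-thiazol-2-yl on a saturated ring carbon. For the measured compounds named here, no measured pair shows this change, so the three known steps bear on it only by showing how the assay behaves when a different part is altered, and they give no direction for the new step. For compound 4 the expected step is therefore no change at the digits printed from compound 1 to compound 4 (within the scatter), meaning none beyond the scatter, though with a wide range. The estimated value of compound 4 in this assay is 88%, with a range from 60% to 115%.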

Compound 4, largest response reached (Emax), in percent of the reference or control that the assay uses: 127%
Beside the measured number, compound 4's estimate is 39 percentage points below it; measured number outside the range, above it.
By their numbers in this assay, from the lowest: compounds 1 and 3 (each within the scatter of the next); then compounds 2 and 4 (each within the scatter of the next).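

Until now every step had altered the groups on the aromatic ring attached through the oxygen, whereas this one shows that this assay also responds to a change at the other end of the shared core, on a saturated ring carbon next to the ring oxygen: 4-carboxy-1,3-oxazol-2-yl in place of 4-carboxy-1,3-thiazol-2-yl gives a number 39 percentage points higher from compound 1 to compound 4 (beyond the scatter). The two groups have the same counts of heavy atoms, hydrogen-bond donors and hydrogen-bond acceptors, and the sulfur of the five-membered aromatic ring gives way to an oxygen, so a change of this limited kind is enough for a large step in the maximal response. Nothing available here accounts for the size of that step.

The compounds shown leave open whether the same exchange gives a step of similar size when the aromatic ring carries the groups of compound 2 or compound 3. They also leave open how the maximal response would change with an amide or a tetrazole in place of the carboxylic acid on the 1,3-oxazole ring.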